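From a fluoro to a trifluoromethoxy group on the amide ring

This account rests on a few compounds, and the source may have more. Where it says the series, first, only, none or still open, it means among the compounds named here.

Compound 1, `CCC(=O)Nc1c(C(O)(C(F)(F)F)C(F)(F)F)ccc2ccccc12`, gives 15 nM in an assay on LtK cells with ATP-sensitive inward rectifier potassium channel 11 (Homo sapiens) as the target; a higher number here means that more compound is needed for the effect, a lower number that less compound is needed.
Compound 2, `N#Cc1cccc(C(=O)Nc2c(C(O)(C(F)(F)F)C(F)(F)F)ccc3ccccc23)c1`, gives 12 nM in this assay.
Compound 3, `O=C(Nc1c(C(O)(C(F)(F)F)C(F)(F)F)ccc2ccccc12)c1ccc(F)cc1`, gives 70 nM in this assay.

All three share the same core and differ only in the group attached to the amide carbonyl. Compound 3 has the highest number of the three: the step from its nearest neighbour is a 4.7-fold higher number from compound 1 to compound 3 (0.67 log units; beyond the scatter), and from the other 5.8-fold higher number from compound 2 to compound 3 (0.77 log units; beyond the scatter); both lie beyond the scatter, so more of compound 3 is needed than of either. The remaining step, a 1.3-fold lower number from compound 1 to compound 2 (0.10 log units; within the scatter), lies within the scatter.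

Compound 4, `O=C(Nc1c(C(O)(C(F)(F)F)C(F)(F)F)ccc2ccccc12)c1ccc(OC(F)(F)F)cc1`, keeps the phenyl ring on the carbonyl of compound 3 and changes one substituent on it: trifluoromethoxy in place of fluoro on an aromatic carbon. For the measured compounds named here, no measured step changes a substituent on that ring; the steps that exist swap the whole group on the carbonyl, and they show that such swaps can move the number by a modest amount. There is therefore no direct guide, and the expectation is that the change stays within the scatter, with a wide range. The expected step is a 1.2-fold lower number from compound 3 to compound 4 (0.07 log units; within the scatter). For compound 4 the estimate in this assay is 60 nM, with a range from 20 nM to 200 nM.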

Compound 4, half-maximal effective concentration: > 10000 nM
Compound 4: no number, only a limit; the forecaster's own chance of this, stated with the estimate: 5%; middle value at least 160-fold (2.22 log units) away from the limit.
By their numbers in this assay, from the lowest: compounds 2 and 1 (each within the scatter of the next); then compound 3. At a limit, above all of these: compound 4.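

The earlier compounds shown here showed swaps of the whole group on the carbonyl moving the number only modestly, whereas changing one substituent on the phenyl ring, trifluoromethoxy in place of fluoro, gives an at least 140-fold higher number from compound 3 to compound 4 (2.15 log units; beyond the scatter) in this assay, so this one place on the ring matters far more than those steps suggested. The other steps to compound 4 are just as large, an at least 660-fold higher number from compound 1 to compound 4 (2.82 log units; beyond the scatter) and an at least 830-fold higher number from compound 2 to compound 4 (2.92 log units; beyond the scatter), which sets it well apart from all three earlier compounds. For compound 4 the reading is a limit and not a number: the limit of > 10000 nM in this assay, at which 1 of the 4 values shown sits.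

With only this one pair on the ring, the compounds shown cannot tell whether the oxygen or the fluorines of the entering group matter, and a methoxy group or a trifluoromethyl group at the same place would separate the two. As far as these compounds go, whether the same swap would act alike on a different ring, such as the 3-cyanophenyl ring of compound 2, also stays open.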